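A few compounds are considered here, and "the series" means these few. Any claim that something is new, unique, unknown or untested is made for them only; others in the source may bear on it.

Compound 1 `O=C(O)CCCCC(CCSC(=O)c1ccccc1)SC(=O)c1ccccc1`: 81%
Compound 2 `O=C(CCCCC(S)CCS)Nc1ccc(F)cc1`: 11.7%
Compound 3 `O=C(CCCCC(CCSC(=O)c1ccccc1)SC(=O)c1ccccc1)Nc1ccccc1`: "not active" (no number reported)

All three were tested in a functional assay on Bel-7402 cells (Homo sapiens) for inhibition, read by MTT assay, with a stated time of 24 h, tested at 100 ug/mL; a lower number here means less inhibition of growth, a higher number more inhibition of growth at the concentration tested. There, compound 3 has no single number, as it is reported only as "not active" (no number reported). Compound 4 `O=C(CCCCC(CCSC(=O)c1ccccc1)SC(=O)c1ccccc1)Nc1ccccc1Cl` is compound 3 with one change: chloro in place of hydrogen on an aromatic carbon, ortho to a large group. Going by the values given here, no measured pair shows this change, so the expectation rests on compound 3 alone, reported as "not active" (no number reported). A small rise in growth inhibition is expected, possibly none beyond the scatter. In this assay, the estimate for compound 4 is 12%, with an expected range of 0% to 40%.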

Compound 4, percent growth inhibition at one concentration: "not active" (no number reported)
Nothing numeric was reported for compound 4; no gap can be computed for the estimate.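

Compound 3 and compound 4 are both reported only as not active in this assay, so no step can be read between them. Going by these compounds, whether the change from phenyl to 2-chlorophenyl affects growth inhibition stays open, and no supporting evidence bears on this result.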